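The compounds below may be only part of what the source reports. "The series", "measured", "known", "first", "only" and "open" are said of these compounds alone.

Of the compounds shown here, two with the same shared core have been measured in a functional assay on HepG2 cells (Homo sapiens) for antiproliferative activity, read by MTT assay; a higher number here means a weaker inhibitor, a lower number a stronger inhibitor. Compound 1 `Nc1c(C(=O)N/N=C/c2ccc(Br)cc2)oc2nc(-c3cccs3)cc(C(F)(F)F)c12` gives 6100 nM in this assay. Compound 2 `Cc1ccc(/C=N/NC(=O)c2oc3nc(-c4ccccc4)cc(C(F)(F)F)c3c2N)cc1`, which carries a phenyl on the core and a methyl on the outer benzene ring, gives 8900 nM. Compound 2 thus sits at the upper end of the two numbers, but its gap to compound 1 is within the usual scatter, so the two cannot be told apart.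

Compound 3 `Nc1c(C(=O)N/N=C/c2ccc(Br)cc2)oc2nc(-c3ccccc3)cc(C(F)(F)F)c12` is not yet measured. It differs from compound 2 in one place: bromo in place of methyl on an aromatic carbon, that is, 4-methylphenyl becomes 4-bromophenyl. Within the data shown here, no measured pair shows this exact exchange on its own. Compound 1, which also carries the bromo, gives 6100 nM, a number close to that of compound 2. The step from compound 2 to compound 3 is therefore expected to be small, a 1.3-fold lower number from compound 2 to compound 3 (0.10 log units; within the scatter), not beyond the scatter. Compound 3 is estimated at 7000 nM, within a range from 3000 nM to 16000 nM.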

Compound 3, half-maximal inhibitory concentration: 19900 nM
Compound 3: middle estimate off by 2.8-fold (0.45 log units), on the low side; the measured number lies above the stated range.
By their numbers in this assay, from the lowest: compounds 1 and 2 (each within the scatter of the next); then compound 3.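

In this assay, bromo in place of methyl on the outer benzene ring is not a neutral exchange when the core carries a phenyl: it gives a weaker inhibitor (a 2.2-fold higher number from compound 2 to compound 3 (0.35 log units; beyond the scatter)). With the 4-bromophenyl held constant, the group on the core also counts, as phenyl in place of thiophen-2-yl gives a weaker inhibitor as well (a 3.3-fold higher number from compound 1 to compound 3 (0.51 log units; beyond the scatter)). Compounds 1 and 2 differ in two places at once, so they could not separate these two changes, and nothing available here explains either step.

Going by these compounds, each exchange is seen only once, so it remains open whether methyl to bromo would have the same effect with thiophen-2-yl on the core. On these data alone, how a methoxy or an amine would compare at the same place on the outer ring also remains open.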